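A few compounds are considered here, and "the series" means these few. Any claim that something is new, unique, unknown or untested is made for them only; others in the source may bear on it.

Measured in a functional assay on ECa-109 cells (Homo sapiens) for antiproliferative activity, read by MTT assay, with a stated time of 72 h; a lower number here means a stronger inhibitor, a higher number a weaker inhibitor:
- compound 1 `CCCSc1nc(N/N=C/c2ccccc2Cl)c2nnn(Cc3ccccc3)c2n1`: 6180 nM
- compound 2 `CCCSc1nc(N/N=C/c2cccs2)c2nnn(Cc3ccccc3)c2n1`: > 64000 nM

Compound 2 stands at the end of the measurable range. As far as these compounds go, its > 64000 nM is a limit of the assay and not a number, so its true position is unknown. For the measured compounds named here, this is the case for one of the two compounds so far: the limit of > 64000 nM in this assay, at which 1 of the 2 values shown sits.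

Compound 3 `CCCSc1nc(N/N=C/c2ccc(N(C)C)cc2)c2nnn(Cc3ccccc3)c2n1` has not yet been measured. It carries 4-(dimethylamino)phenyl in place of thiophen-2-yl on a carbon with a double bond to nitrogen.

Going by the values given here, only one measured step bears on this change, and it falls at the same place in the molecule. That step is large: an at least 10-fold higher number from compound 1 to compound 2 (1.01 log units; beyond the scatter). Compound 3 regains a six-membered aromatic ring of carbon only, so a lower number than the limit of compound 2 is expected in this assay, with only part of the gap to compound 1 recovered. With a single step as precedent, the expectation is loose, and a further limit remains possible.

The expected change is an at least 3.5-fold lower number from compound 2 to compound 3 (0.55 log units; beyond the scatter). For compound 3 the estimated value is 18000 nM, with an expected range of 5000 nM to 60000 nM.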

Compound 3, half-maximal inhibitory concentration: 20000 nM
For compound 3 the middle estimate is 1.1-fold (0.05 log units) below the measured one, within the range that was stated.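

At the group on a carbon with a double bond to nitrogen, this assay now gives a step away from thiophen-2-yl that ends in a measured value: an at least 3.2-fold lower number from compound 2 to compound 3 (0.50 log units; beyond the scatter). The size of this step is open on one side, since the value of compound 2 is a limit and not a number: the limit of > 64000 nM in this assay, at which 1 of the 3 values shown sits A six-membered aromatic ring of carbon only does not by itself restore the level of compound 1, as 4-(dimethylamino)phenyl and 2-chlorophenyl remain apart, with a 3.2-fold higher number from compound 1 to compound 3 (0.51 log units; beyond the scatter).

The two phenyl groups differ in both the substituent and where it stands, so the compounds shown cannot say which of these separates compound 1 from compound 3; an unsubstituted phenyl or a 4-chlorophenyl group would divide the two effects. Thiophen-2-yl is also the only five-membered ring here, so it remains open whether the weak result belongs to that ring alone or extends to a furan-2-yl group, or how a pyridine ring would compare.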